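Bromophenyl-to-difluorophenyl swap on the chalcone series

The source may report more compounds than this note shows. Statements on the series, on what has been measured and on what is new or still open speak of the compounds shown alone.

Compound 1 `O=C(COc1ccc(C(=O)/C=C/c2ccccc2Br)cc1)N[C@H]1CCOC1=O` gives 15300 nM in a functional assay on MCF7 cells (Homo sapiens) for antiproliferative activity, read by MTT assay, with a stated time of 72 h; a higher number here means a weaker inhibitor, a lower number a stronger inhibitor. Compound 2 `O=C(COc1ccc(C(=O)/C=C/c2ccc(Br)cc2)cc1)N[C@H]1CCOC1=O` reaches only a limit in this assay, > 64000 nM. Going by the values given here, the step of an at least 4.1-fold higher number from compound 1 to compound 2 (0.62 log units; beyond the scatter) is therefore the one measured change on this aromatic ring. Compound 3 `O=C(CNc1ccc(F)cc1)N[C@H]1CCOC1=O` likewise returns a limit, > 64000 nM. Compound 2 thus stands at the limit of > 64000 nM in this assay, at which 2 of the 3 values shown sit, with no number of its own. Compound 4 `O=C(COc1ccc(C(=O)/C=C/c2ccc(F)c(F)c2)cc1)N[C@H]1CCOC1=O` differs from compound 2 by 3,4-difluorophenyl in place of 4-bromophenyl on a double-bonded chain carbon bound to a double-bonded chain carbon. Among the compounds with values here, only the step from compound 1 to compound 2 bears on this ring, and it concerns bromophenyl isomers, not fluorine; no measured step covers fluorinated aryl here. Compound 4 is therefore expected near the limit, a step of an at least 1.4-fold lower number from compound 2 to compound 4 (0.15 log units; that floor lies within the scatter) not clearly beyond the scatter. The estimate for compound 4 is 45000 nM, within 12000 nM to 150000 nM.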

Compound 4, half-maximal inhibitory concentration: > 64000 nM
Compound 4: a limit, no number (the forecaster's own chance of this, stated with the estimate: 55%); middle value at least 1.4-fold (0.15 log units) from the limit.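

Compound 4, carrying 3,4-difluorophenyl at this place, also returns only a limit in this assay, so a second replacement for 2-bromophenyl gives no number: the limit of > 64000 nM in this assay, at which 3 of the 4 values shown sit. Going by these compounds alone, the change from 2-bromophenyl to 3,4-difluorophenyl gives an at least 4.1-fold higher number from compound 1 to compound 4 (0.62 log units; beyond the scatter), and 2-bromophenyl remains the only group at this place with a measured number. The step between the two limits cannot be read.

As far as these compounds go, whether any other group on this double-bonded chain carbon retains a measurable value stays open. A chlorophenyl group would test whether a measurable value depends on bromine.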